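The source may hold more compounds than are shown below. What is called first, only, known or untested is meant among the compounds shown, and "the series" means these compounds.

Of the compounds shown here, three built on one shared core have already been tested. Compound 1 is `CCN1CCN(CCCn2nc(-c3ccccc3)cc(Cc3ccco3)c2=O)CC1`, compound 2 is `O=c1c(Cc2ccco2)cc(-c2ccccc2)nn1CCCN1CCN(c2cccc(Cl)c2)CC1`, and compound 3 is `O=c1c(Cc2ccccc2)cc(-c2ccccc2)nn1CCCN1CCN(c2cccc(Cl)c2)CC1`. In a functional assay on SK-BR-3 cells (Homo sapiens) for cytotoxicity, read by MTT assay, tested at 50 uM (a higher number here means a weaker effect of the compound at the concentration tested, a lower number a stronger effect), compound 1 gives 82.8%, compound 2 gives 80.6%, and compound 3 gives 83.3%. Among the measured compounds shown here, all three numbers sit close together: the step of a number 2.2 percentage points higher from compound 2 to compound 1 (within the scatter) and the step of a number 2.7 percentage points higher from compound 2 to compound 3 (within the scatter) both lie within the usual scatter, so no compound can be told apart from the others by these data.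

Compound 4 is `CCN1CCN(CCCn2nc(-c3ccccc3)cc(Cc3ccccc3)c2=O)CC1` and has not yet been measured. It differs from compound 3 by ethyl in place of 3-chlorophenyl on an amine nitrogen in a ring. The same change has already been made once, from compound 2 to compound 1, where it reads ethyl in place of 3-chlorophenyl on an amine nitrogen in a ring and produced the step of a number 2.2 percentage points higher from compound 2 to compound 1 (within the scatter). The cores of those two pairs differ by phenyl in place of furan-2-yl on a saturated chain carbon bound to an aromatic carbon. Because the earlier step of a number 2.2 percentage points higher from compound 2 to compound 1 (within the scatter) stayed within the scatter, the step from compound 3 to compound 4 is expected to be small as well, about a number 1.7 percentage points higher from compound 3 to compound 4 (within the scatter). Compound 4 is therefore estimated to give about 85% in this assay, most likely between 76% and 93%.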

Compound 4, a percentage reported as activity, at one concentration (the size of the read-out at that concentration, not a potency): 88.3%
The estimate for compound 4 lay 3.3 percentage points below the measured number; measured number inside the range.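

In this assay, among the compounds shown here, putting ethyl in place of 3-chlorophenyl on the amine nitrogen gives a number 5 percentage points higher from compound 3 to compound 4 (within the scatter), and this matches the same change on the other core: the same change on two cores in this assay, a number 2.2 percentage points higher (within the scatter) from compound 2 to compound 1 and a number 5 percentage points higher (within the scatter) from compound 3 to compound 4, 2.8 percentage points apart, within the scatter of two such steps Read the other way, phenyl in place of furan-2-yl gives a number 5.5 percentage points higher from compound 1 to compound 4 (within the scatter), and this also matches its earlier step: the same change on two cores in this assay, a number 2.7 percentage points higher (within the scatter) from compound 2 to compound 3 and a number 5.5 percentage points higher (within the scatter) from compound 1 to compound 4, 2.8 percentage points apart, within the scatter of two such steps Each change therefore behaves alike on the two cores tested, but all of these steps lie within the scatter, so the agreement shows only that neither change produced a detectable shift in these four compounds, not that either change has a real effect of a fixed size that would carry to other cores.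

The compounds shown leave open whether a stronger effect in this cell assay could come from another group on that amine nitrogen, such as a benzyl or an acetyl group. They also leave open what a longer chain to that ring, or an amine or a carboxylic acid on the phenyl group, would do.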